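The source may hold more compounds than are shown below. What is called first, only, known or untested is meant among the compounds shown, and "the series" means these compounds.

Measured so far in a functional assay (aorta) with Rattus norvegicus as the target; a lower number here means a less potent compound, a higher number a more potent compound, by a factor of ten per unit of this negative logarithm:
compound 1, `CCC(=O)c1ccc2c(c1)C(n1ccccc1=O)=CC(C)(C)O2`, gives 6.63
compound 2, `CC1(C)C=C(n2ccccc2=O)c2cc(C(=O)c3ccccc3)ccc2O1`, gives 6.61
compound 3, `CC1(C)C=C(n2ccccc2=O)c2cc(C(=O)c3ccccc3[N+](=O)[O-])ccc2O1`, gives 6.17

Compound 3 sits lowest of the three, with compound 2 nearest and compound 1 furthest. The gaps are a number 0.44 log units lower from compound 2 to compound 3 (beyond the scatter) and a number 0.46 log units lower from compound 1 to compound 3 (beyond the scatter). Compound 4, `CC1(C)C=C(n2ccccc2=O)c2cc(C(=O)c3c(F)cccc3F)ccc2O1`, follows from compound 3 by 2,6-difluorophenyl in place of 2-nitrophenyl on a carbonyl carbon. Among the compounds with values here, two measured steps bear on it: a number 0.44 log units lower from compound 2 to compound 3 (beyond the scatter) shows a modest loss when the nitro enters, while a number 0.02 log units lower from compound 1 to compound 2 (within the scatter) shows that ethyl against phenyl on the carbonyl carbon stays within the scatter. Within the data shown here, in compound 4 the nitro leaves and a 2,6-difluorophenyl enters, for which no precedent exists; a modest rise back toward the level of compound 2 is expected, a number 0.33 log units higher from compound 3 to compound 4 (beyond the scatter). Compound 4 is therefore estimated at 6.5, range 6.1 to 6.9.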

Compound 4, logarithm of the reciprocal of the active concentration, log(1/C): 6.97
Compound 4: middle estimate off by 0.47 log units, on the low side, outside the stated range (above it).
By their numbers in this assay, from the lowest: compound 3; then compounds 2 and 1 (each within the scatter of the next); then compound 4.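

In this assay, this position proves able to lift the number, which ethyl and phenyl on the carbonyl carbon had not shown: 2,6-difluorophenyl gives a number 0.36 log units higher from compound 2 to compound 4 (beyond the scatter) against phenyl and a number 0.34 log units higher from compound 1 to compound 4 (beyond the scatter) against ethyl. Substitution on the phenyl now moves the number both ways, and the two substituted rings stand well apart with a number 0.80 log units higher from compound 3 to compound 4 (beyond the scatter). Compound 4 is the highest of the four.

No supporting measurement bears on why these steps occur. Open, from the compounds shown here alone, is whether 2-fluorophenyl or 2,6-dichlorophenyl on the carbonyl carbon would match compound 4.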